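Working notes: aryl substituent change from compound 1 to compound 4

A few compounds are considered here, and "the series" means these few. Any claim that something is new, unique, unknown or untested is made for them only; others in the source may bear on it.

Measured in an assay on microsomes for inhibition of acyl-CoA:cholesterol acyltransferase (Oryctolagus cuniculus); a higher number here means a weaker inhibitor, a lower number a stronger inhibitor:
compound 1 `CC(C)c1cccc(C(C)C)c1NC(=O)NCC1(c2ccc(Cl)cc2)CCCC1` gives 32 nM
compound 2 `CC(C)c1cccc(C(C)C)c1NC(=O)NCC1(c2cccc(OCc3ccccc3)c2)CCCC1` gives 30 nM
compound 3 `CC(C)c1cccc(C(C)C)c1NC(=O)NCC1(c2ccccc2C(F)(F)F)CCCC1` gives 18 nM

Among these three, compound 1 has the highest number, but its gaps to compound 2 and to compound 3 both fall within the scatter, so the three stand on a level in this assay. Going by the values given here, the only single-point step among them, a 1.8-fold lower number from compound 1 to compound 3 (0.25 log units; within the scatter), likewise remains within the scatter: swapping one aryl substituent for another has so far moved nothing that can be read as real.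

Compound 4 `CC(C)c1cccc(C(C)C)c1NC(=O)NCC1(c2ccc(N)cc2)CCCC1` differs from compound 1 by amino in place of chloro on an aromatic carbon. Among the compounds with values here, no measured step replaces a halogen with a group carrying a hydrogen-bond donor and acceptor, so nothing bears on this change directly; the known steps only show that the aryl ring tolerates varied substituents without a shift beyond the scatter. Given the flat values of compound 1, compound 2 and compound 3, a modest weakening is expected for compound 4, with the step of a 2.5-fold higher number from compound 1 to compound 4 (0.40 log units; beyond the scatter) estimated to lie at or just beyond the scatter. Compound 4 is expected to give about 80 nM in this assay, with a range from 25 nM to 300 nM.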

Compound 4, half-maximal inhibitory concentration: 29 nM
For compound 4 the middle estimate is 2.8-fold (0.44 log units) above the measured one; measured number inside the range.
By their numbers in this assay, from the lowest: compounds 3, 4, 2 and 1 (each within the scatter of the next).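

In this assay, the step of a 1.1-fold lower number from compound 1 to compound 4 (0.04 log units; within the scatter) shows that, on this aromatic carbon para to a large group, chloro and amino stand level, even though amino brings a hydrogen-bond donor and acceptor and chloro brings neither. Going by these compounds alone, the earlier compounds varied the aryl substituent only among groups without a hydrogen-bond donor, so this is the first sign that such a donor can enter here without a shift that can be read as real; the step of a 1.6-fold higher number from compound 3 to compound 4 (0.21 log units; within the scatter) likewise places 4-aminophenyl level with 2-(trifluoromethyl)phenyl. Nothing further is available to explain this level result.

The compounds shown leave open whether this tolerance extends to other groups at the same place, such as dimethylamino, acetamido or a carboxylic acid, which would separate the effect of the amine hydrogens from that of the nitrogen and test a charged group. Within the data shown here, it also remains open whether any substituent at this place gives a step beyond the scatter, since every step so far lies within it.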